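The compounds below may be only part of what the source reports. "The series", "measured", "known", "first", "only" and "open" are said of these compounds alone.

Working notes on the series. Three compounds of the shared core have numbers in an assay on isolated protein for inhibition of complement C1r subcomponent (Homo sapiens); a higher number here means a weaker inhibitor, a lower number a stronger inhibitor. Compound 1 `O=c1oc(-c2ccccc2C(F)(F)F)nc2ccccc12` gives 4200 nM. Compound 2 `O=c1oc(-c2ccccc2I)nc2ccc(Cl)cc12` gives 3000 nM, the second highest of the three numbers; compound 1 lies nearest to it, within the scatter. Compound 3 `O=c1oc(-c2ccccc2I)nc2cc(Cl)c(Cl)cc12` gives 1700 nM and lies furthest from compound 2, also within the scatter. Among the compounds with values here, the only measured step between compounds that differ in one place is a 1.8-fold lower number from compound 2 to compound 3 (0.25 log units; within the scatter), a chloro entering on an aromatic carbon of the core.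

Compound 4 `COc1ccc2nc(-c3ccccc3I)oc(=O)c2c1` is not yet measured. It differs from compound 2 by methoxy in place of chloro on an aromatic carbon, the place being part of a fused or bridged system of two rings. Within the data shown here, no measured step swaps one substituent for another at this place; the step that bears on it most, a 1.8-fold lower number from compound 2 to compound 3 (0.25 log units; within the scatter), concerns a chloro entering elsewhere on the core and did not move the number beyond the scatter. On that basis the expected step from compound 2 to compound 4 is none beyond the scatter, a 1.2-fold higher number from compound 2 to compound 4 (0.07 log units; within the scatter). Compound 4 is therefore estimated at 3500 nM in this assay, with a range from 1500 nM to 8000 nM.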

Compound 4, half-maximal inhibitory concentration: 5000 nM
For compound 4 the middle estimate is 1.4-fold (0.15 log units) below the measured one; the measured number falls inside the stated range.
By their numbers in this assay, from the lowest: compounds 3, 2, 1 and 4 (each within the scatter of the next, the first and the last beyond it).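

Within the data shown here, this is the first exchange of one substituent for another at this place, an aromatic carbon of the six-membered aromatic ring of carbon only, and in this assay it gives a 1.7-fold higher number from compound 2 to compound 4 (0.22 log units; within the scatter). Methoxy in place of chloro adds one heavy atom and one hydrogen-bond acceptor at this place, yet the number does not move beyond the scatter, so this change shows no measurable effect in this assay. No measurement is available that could explain the outcome of this exchange.

With only chloro and methoxy shown at this place, it remains open whether an amine, a carboxylic acid or a longer chain would move the number beyond the scatter. Also open, from the compounds shown here alone, are where hydrogen at this place would stand and whether methoxy would give a similar number alongside the second chloro of compound 3.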